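Ester chain extension on the dichloro-free chloro analogue

The source may report more compounds than this note shows. Statements on the series, on what has been measured and on what is new or still open speak of the compounds shown alone.

Compound 2 `CCc1c(C(=O)OC)[n+]([O-])c2cc(Cl)ccc2[n+]1[O-]` gives in an ADME assay on Vero cells (Chlorocebus sabaeus) for cytotoxicity (on this read-out higher numbers stand for weaker inhibition and lower numbers for stronger inhibition), only a limit, > 10 ug/mL, not a number, and this is the limit at which (the limit of > 10 ug/mL in this assay, at which 1 of the 3 values shown sits). The neighbours set the frame: compound 1 `CCc1c(C(=O)OC)[n+]([O-])c2cc(OC)ccc2[n+]1[O-]` gives 40 ug/mL in this assay, and compound 3 `CCc1c(C(=O)OC)[n+]([O-])c2cc(Cl)c(Cl)cc2[n+]1[O-]` gives 4 ug/mL. The step that the limit leaves unreadable from compound 1 to compound 2 cannot be sized, whereas an at least 2.5-fold lower number from compound 2 to compound 3 (0.39 log units; beyond the scatter) is readable and lowers the number. Compound 4 `CCOC(=O)COC(=O)c1c(CC)[n+]([O-])c2ccc(Cl)cc2[n+]1[O-]` differs from compound 2 by ethoxycarbonyl in place of hydrogen on a saturated chain carbon bound to an oxygen next to a carbonyl group. Among the compounds with values here, no measured step touches the ester side chain; both measured steps change the aromatic substituents, so none bears directly on this change. With compound 2 fixed only by its limit and the ring substituents unchanged, a step of no clear size beyond the scatter is expected in this assay, and the estimate for compound 4 is 16 ug/mL with a range from 5 ug/mL to 50 ug/mL, meaning an expected step that the limit leaves unreadable from compound 2 to compound 4 that stays within the uncertainty set by the limit of compound 2.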

Compound 4, half-maximal inhibitory concentration: 1.89 ug/mL
Compound 4: middle estimate off by 8.5-fold (0.93 log units), on the high side, outside the stated range (below it).
By their numbers in this assay, from the lowest: compound 4; then compound 3; then compound 1.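

Work on the ester side chain, and not only on the aromatic substituents, moves the number in this assay: ethoxycarbonyl in place of hydrogen on a saturated chain carbon bound to an oxygen next to a carbonyl group gives an at least 5.2-fold lower number from compound 2 to compound 4 (0.72 log units; beyond the scatter). On this read-out a lower number means stronger inhibition, so this position is not silent for cytotoxicity. The full size of the step stays unknown, and the step from compound 1 to compound 2 cannot be read, as compound 2 is held only by a limit: the limit of > 10 ug/mL in this assay, at which 1 of the 4 values shown sits.

From the compounds shown here alone, whether a carboxylic acid, an amine or a longer chain at this place would shift the number in the same direction stays open. Going by these compounds, whether the change acts alike with the methoxy of compound 1 or the two chloro substituents of compound 3 also stays open.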